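This account rests on a few compounds, and the source may have more. Where it says the series, first, only, none or still open, it means among the compounds named here.

Three compounds have been measured in a functional assay on BGC-823 cells (Homo sapiens) for inhibition, read by MTT assay, with a stated time of 72 h (a lower number here means a stronger inhibitor, a higher number a weaker inhibitor), so far:

- compound 1 `O=C1Nc2ccccc2/C1=C\C(=O)c1cccc(Cl)c1` gives 7700 nM
- compound 2 `CCC(=O)Nc1cccc(C(=O)/C=C2/C(=O)Nc3ccccc32)c1` gives 7500 nM
- compound 3 `CC(C)C(=O)Nc1cccc(C(=O)/C=C2/C(=O)Nc3ccccc32)c1` gives 6200 nM

Compound 3 stands within the scatter of both other compounds, as shown by a 1.2-fold lower number from compound 2 to compound 3 (0.08 log units; within the scatter) and by a 1.2-fold lower number from compound 1 to compound 3 (0.09 log units; within the scatter). Compound 4 `CC(=O)Nc1cccc(C(=O)/C=C2/C(=O)Nc3ccccc32)c1` has not yet been measured. It differs from compound 3 by methyl in place of isopropyl on a carbonyl carbon, (methyl in place of isopropyl on a carbonyl carbon), which also reads as isopropylcarbonyl to acetyl.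

The closest evidence is a step at the same chain, methyl in place of hydrogen, which gave a 1.2-fold lower number from compound 2 to compound 3 (0.08 log units; within the scatter). The exchange of chloro for propanoylamino gave a 1.0-fold lower number from compound 1 to compound 2 (0.01 log units; within the scatter). Both steps lie within the scatter, so no step beyond the scatter is expected in this assay, and no direction is favoured. The expected step is a 1.1-fold higher number from compound 3 to compound 4 (0.05 log units; within the scatter). Compound 4 is estimated at 7000 nM, with an expected range from 3500 nM to 14000 nM.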

Compound 4, half-maximal inhibitory concentration: 9100 nM
For compound 4 the middle estimate is 1.3-fold (0.11 log units) below the measured one; the measured number falls inside the stated range.
By their numbers in this assay, from the lowest: compounds 3, 2, 1 and 4 (each within the scatter of the next).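

Across the amides in this assay, methyl in place of isopropyl on the carbonyl carbon gives the largest step seen so far, and it still lies within the scatter (a 1.5-fold higher number from compound 3 to compound 4 (0.17 log units; within the scatter)). Hydrogen in place of methyl on the saturated chain carbon (a 1.2-fold higher number from compound 2 to compound 4 (0.08 log units; within the scatter)) and acetamido in place of chloro on the aromatic carbon (a 1.2-fold higher number from compound 1 to compound 4 (0.07 log units; within the scatter)) also stay within the scatter, so across these four compounds neither the size of the group on the carbonyl carbon nor the exchange of chloro for acetamido separates the numbers. Nothing available here bears on the reason for these numbers.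

The compounds shown leave open whether a longer chain or a phenyl group on the carbonyl carbon would give a step beyond the scatter. They also leave open what a free amine or a carboxylic acid on that aromatic carbon would give.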